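Anilinoenone series: indolyl to methoxyphenyl on the amine

A few compounds are considered here, and "the series" means these few. Any claim that something is new, unique, unknown or untested is made for them only; others in the source may bear on it.

Measured so far in a functional assay on A549 cells (Homo sapiens) for cytotoxicity, read by MTT assay, with a stated time of 48 h; a higher number here means a weaker inhibitor, a lower number a stronger inhibitor:
- compound 1 `O=C(/C=C\Nc1ccc2cc[nH]c2c1)c1nc(-c2ccc(C(F)(F)F)cc2)n2ccccc12` gives > 30000 nM, a limit of the assay.
- compound 2 `COc1ccc(N/C=C\C(=O)c2nc(-c3ccc(F)cc3)n3ccccc23)cc1OC` gives > 30000 nM, a limit of the assay.
- compound 3 `Cc1cc2cc(N/C=C\C(=O)c3nc(-c4ccc(F)cc4)n4ccccc34)ccc2[nH]1` gives > 30000 nM, a limit of the assay.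

Compound 1 stands only as a limit in this assay, and the two other values are limits as well, so no order among compounds 1, 2 and 3 can be read (the limit of > 30000 nM in this assay, at which 3 of the 3 values shown sit). Among the measured compounds shown here, the one measured step with a single change, a step that the two limits leave unreadable from compound 2 to compound 3, has no readable size either.

Compound 4 `COc1ccc(N/C=C\C(=O)c2nc(-c3ccc(C(F)(F)F)cc3)n3ccccc23)cc1` differs from compound 1 by 4-methoxyphenyl in place of 1H-indol-6-yl on an amine nitrogen. For the measured compounds named here, no measured step bears directly on this change; the nearest comparison, a step that the two limits leave unreadable from compound 2 to compound 3, also exchanges an indolyl for a methoxy-bearing phenyl on the amine nitrogen and gives no readable size, so the expectation for compound 4 in this assay is no step beyond the scatter, with the value most likely again reported as a limit. The estimated step that the limit leaves unreadable from compound 1 to compound 4 is expected to lie within the scatter. Compound 4 is estimated at 45000 nM, with a range from 15000 nM to 150000 nM.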

Compound 4, half-maximal inhibitory concentration: 21800 nM
Estimate against measurement, compound 4: 2.1-fold (0.31 log units) above; the measured number falls inside the stated range.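

In this assay, among the compounds shown here, the exchange of 1H-indol-6-yl for 4-methoxyphenyl on the amine nitrogen gives an at least 1.3-fold lower number from compound 1 to compound 4 (0.13 log units; that floor lies within the scatter) and so the first step with a direction, though only its floor can be read and that floor does not clear the scatter. Compound 4 is the only compound shown that carries a number, so the 4-methoxyphenyl group gives the series its first point off the limit, and the others remain limits: the limit of > 30000 nM in this assay, at which 3 of the 4 values shown sit. The remaining step, between the two limits, cannot be read.

Going by these compounds, how far compound 1 truly lies from compound 4 stays open, since the limit fixes only a floor for that step. Also open, on these data alone, is how a 4-hydroxyphenyl or a 4-aminophenyl group on the amine nitrogen would read in this assay on the same core.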